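This account rests on a few compounds, and the source may have more. Where it says the series, first, only, none or still open, it means among the compounds named here.

Of the compounds shown here, two built on the same core have been measured. Compound 1 `O=C(O)c1ccc(C#Cc2ccc3c(c2)C=C([N+](=O)[O-])C(C(F)(F)F)O3)cc1` carries a hydroxy group on its carbonyl carbon, and in a functional assay on 1321N1 cells for antagonist activity at P2Y purinoceptor 6 (Homo sapiens), read by fluorescence and calcium flux (a higher number here means a weaker inhibitor, a lower number a stronger inhibitor), compound 1 gives 1090 nM. Compound 2 `COC(=O)[C@H](C)NC(=O)c1ccc(C#Cc2ccc3c(c2)C=C([N+](=O)[O-])C(C(F)(F)F)O3)cc1` carries a (1-(methoxycarbonyl)ethyl)amino group in place of that hydroxy, and in this assay compound 2 gives 6840 nM. For the measured compounds named here, the one step known so far, a 6.3-fold higher number from compound 1 to compound 2 (0.80 log units; beyond the scatter), leaves compound 2 with the highest of the two numbers, that is, as the weaker inhibitor of the pair.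

Compound 3 `NC(=O)NCCNC(=O)c1ccc(C#Cc2ccc3c(c2)C=C([N+](=O)[O-])C(C(F)(F)F)O3)cc1` keeps the amide-type nitrogen of compound 2 and changes only what sits on it: 2-ureidoethyl in place of 1-(methoxycarbonyl)ethyl on an amide-type nitrogen. Going by the values given here, no measured step compares two such amides with each other; the only step available replaces a hydroxy with an amide, which is a different kind of change. The expectation for compound 3 therefore leans on compound 2 alone, whose value 6840 nM sets the starting point, with a step expected to stay within the scatter, a 1.2-fold lower number from compound 2 to compound 3 (0.09 log units; within the scatter). Compound 3 is estimated at 5500 nM, with a range from 1500 nM to 20000 nM.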

Compound 3, half-maximal inhibitory concentration: 10600 nM
Compound 3: the middle estimate sits 1.9-fold (0.28 log units) below what was measured; low and high end bracket the measured number.
By their numbers in this assay, from the lowest: compound 1; then compounds 2 and 3 (each within the scatter of the next).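

Replacing 1-(methoxycarbonyl)ethyl with 2-ureidoethyl on the amide-type nitrogen gives a 1.5-fold higher number from compound 2 to compound 3 (0.19 log units; within the scatter), so this assay does not separate these two chains, even though 2-ureidoethyl brings hydrogen-bond donors that 1-(methoxycarbonyl)ethyl lacks and has no defined stereocentre. The comparison with the hydroxy on the carbonyl carbon of compound 1 now rests on two different chains, a 6.3-fold higher number from compound 1 to compound 2 (0.80 log units; beyond the scatter) and a 9.7-fold higher number from compound 1 to compound 3 (0.99 log units; beyond the scatter), and both steps go in the same direction, towards weaker inhibition, with neither of the two amides going against this. No measurement shown here explains either the shift away from compound 1 or the lack of separation between the two amides.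

On these data alone, both chains on the nitrogen have the same count of heavy atoms and no ring, so it remains open whether size or the end group matters at this position. A small methyl, a chain ending in a free carboxylic acid or an amine, or a longer chain could show whether any amide here can match compound 1 or whether this flat result holds more widely.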